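The source may hold more compounds than are shown below. What is called first, only, known or untested is meant among the compounds shown, and "the series" means these compounds.

Of the compounds shown here, three have been tested in a functional assay on ACHN cells (Homo sapiens) for cytotoxicity, read by MTT assay, with a stated time of 48 h; a higher number here means a weaker inhibitor, a lower number a stronger inhibitor. Compound 1 `COc1ccc(-c2cc(C(=O)Nc3nc4ccc(Cl)cc4s3)nc3cc(-c4ccccc4)nn23)cc1` gives 7240 nM in this assay. Compound 2 `COc1ccc(-c2cc(C(=O)Nc3nc4ccc(Cl)cc4s3)nc3cc(-c4ccccc4)nn23)cc1OC` differs from it by methoxy in place of hydrogen on an aromatic carbon and gives 7760 nM in this assay, so that a 1.1-fold higher number from compound 1 to compound 2 (0.03 log units; within the scatter). Compound 3 `COc1ccc2nc(NC(=O)c3cc(-c4ccc(OC)c(OC)c4)n4nc(-c5ccccc5)cc4n3)sc2c1` gives 13300 nM in this assay, and a 1.7-fold higher number from compound 2 to compound 3 (0.23 log units; within the scatter). All three numbers lie close together.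

Compound 4 `COc1ccc2nc(NC(=O)c3cc(-c4cc(OC)c(OC)c(OC)c4)n4nc(-c5ccccc5)cc4n3)sc2c1` has not yet been measured. It differs from compound 3 by methoxy in place of hydrogen on an aromatic carbon. This is the same kind of change as that between compound 1 and compound 2, but the surroundings are not identical: in compound 4 the entering group is also meta to a methoxy group, which is not the case in compound 2. The difference between the cores of compound 1 and compound 3 is not broken down here.

Because the earlier step of this kind a 1.1-fold higher number from compound 1 to compound 2 (0.03 log units; within the scatter) stayed within the scatter, the step is expected to be about a 1.1-fold higher number from compound 3 to compound 4 (0.05 log units; within the scatter). Compound 4 is therefore estimated at 15000 nM, with an expected range from 7000 nM to 32000 nM.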

Compound 4, half-maximal inhibitory concentration: 5240 nM
The estimate for compound 4 lay 2.9-fold (0.46 log units) above the measured number; measured number outside the range, below it.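

In this assay, extending 3,4-dimethoxyphenyl to 3,4,5-trimethoxyphenyl gives a 2.5-fold lower number from compound 3 to compound 4 (0.40 log units; beyond the scatter), a modest gain in strength. The same kind of change, methoxy in place of hydrogen on an aromatic carbon, therefore does not carry a fixed effect from one core to another in this series: the same change on two cores in this assay, a 1.1-fold higher number (0.03 log units; within the scatter) from compound 1 to compound 2 and a 2.5-fold lower number (0.40 log units; beyond the scatter) from compound 3 to compound 4, 2.7-fold (0.43 log units) apart, beyond the scatter of two such steps. This does not show why the two steps differ, since the two pairs differ both in the core and in how many methoxy groups the phenyl ring already carries, and two pairs cannot separate these influences or support a general rule.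

The compounds shown leave open whether the 3,4,5-trimethoxyphenyl group would give a similar step on the core of compound 1, which would help separate the core from the ring's existing methoxy groups. They also leave open how a different group at the same place, such as a hydroxyl, an amine or a carboxylic acid, would behave on either core.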